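The source may report more compounds than this note shows. Statements on the series, on what has been measured and on what is new or still open speak of the compounds shown alone.

Compound 2 `O=C(Nc1cccc(C(=O)O/N=C2\CCCc3onc(-c4ccccc4F)c32)c1)c1cccc(F)c1` is measured in a functional assay on MDA-MB-231 cells (Homo sapiens) for antiproliferative activity, read by MTT assay, with a stated time of 72 h (a lower number here means a stronger inhibitor, a higher number a weaker inhibitor), and gives 6200 nM. Going by the values given here, its only comparator is compound 1 `O=C(Nc1cccc(C(=O)O/N=C2\CCCc3onc(-c4cccc(F)c4)c32)c1)c1cccc(F)c1`, which in this assay gives 8700 nM. The two differ by a 1.4-fold lower number from compound 1 to compound 2 (0.15 log units; within the scatter), a step that lies within the scatter, so compound 2 cannot be separated from compound 1 on the numbers shown; it holds the smaller of two numbers that are, in effect, the same.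

Compound 3 `COc1ccc(-c2noc3c2/C(=N/OC(=O)c2cccc(NC(=O)c4cccc(F)c4)c2)CCC3)cc1OC` is reached from compound 2 by the change (3,4-dimethoxyphenyl in place of 2-fluorophenyl on an aromatic carbon). Among the compounds with values here, the one measured step, from compound 1 to compound 2, only moves a fluorine around a phenyl ring and did not reach beyond the scatter; nothing measured bears on replacing that ring with a 3,4-dimethoxyphenyl. Compound 3 is therefore expected to give a number close to that of compound 2, with no step beyond the scatter in either direction, and the step of a 1.0-fold higher number from compound 2 to compound 3 (0.02 log units; within the scatter) is the expected one. The estimate for compound 3 in this assay is 6500 nM, with a range from 2000 nM to 20000 nM.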

Compound 3, half-maximal inhibitory concentration: > 25000 nM
Compound 3 ended at the assay's limit; the forecaster's own chance of this, stated with the estimate: 5%; at least 3.8-fold (0.58 log units) between middle value and limit.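

In this assay compound 3 stands at a limit of the assay, > 25000 nM, and this is a limit, not a number. Moving a fluorine around the phenyl ring had left the numbers within the scatter, but 3,4-dimethoxyphenyl on this aromatic carbon gives an at least 4.0-fold higher number from compound 2 to compound 3 (0.60 log units; beyond the scatter) and an at least 2.8-fold higher number from compound 1 to compound 3 (0.45 log units; beyond the scatter), so this position does respond to the group it carries. How far the true value lies past these steps cannot be read: the limit of > 25000 nM in this assay, at which 1 of the 3 values shown sits.

The compounds shown leave open whether a plain phenyl, a phenyl with a single methoxy group, or a phenyl bearing an amine or a carboxylic acid would stay near compound 2 or fall with compound 3. They also leave open whether any group here can give a number clearly lower than those of compound 1 and compound 2.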